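Swapping the group on the carbonyl carbon of compound 3

A few compounds are considered here, and "the series" means these few. Any claim that something is new, unique, unknown or untested is made for them only; others in the source may bear on it.

- compound 1 `O=C(NCc1ccc(S(=O)(=O)c2cccc(F)c2)cc1)c1cc2cnccc2[nH]1` gives 79% as its value
- compound 2 `O=C(NCc1ccc(S(=O)(=O)N2CCCCC2)cc1)c1cc2cnccc2s1` gives 15% as its value
- compound 3 `O=C(NCc1ccc(S(=O)(=O)N2CCCCC2)cc1)c1cc2cnccc2o1` gives 46% as its value

In an ADME assay on microsomes from liver (Homo sapiens) for metabolic stability, read by LC-MS, with a stated time of 30 min, tested at 1 uM (on this read-out lower numbers stand for a less stable compound and higher numbers for a more stable compound), compound 3 at 46% stands second highest of the three, well over compound 2 and well under compound 1. Compound 4 `O=C(NCc1ccc(S(=O)(=O)N2CCCCC2)cc1)c1cc2ccncc2[nH]1` differs from compound 3 on a carbonyl carbon by a group of 9 heavy atoms (7 carbon, 2 nitrogen; one five-membered aromatic ring with 1 hetero atom, one six-membered aromatic ring with 1 hetero atom) in place of a group of 9 heavy atoms (7 carbon, 1 nitrogen, 1 oxygen; one five-membered aromatic ring with 1 hetero atom, one six-membered aromatic ring with 1 hetero atom), on a carbonyl carbon and nowhere else. For the measured compounds named here, the one measured step at this place is a number 31 percentage points higher from compound 2 to compound 3 (beyond the scatter) and it was large, but it exchanges another pair of groups and gives no direction here. Compound 1 at 79% also has a hydrogen-bond donor in the group on its carbonyl carbon, yet it differs elsewhere too, so it only slightly favours a rise. A small upward move within the scatter is expected, the estimated step being a number 8 percentage points higher from compound 3 to compound 4 (within the scatter) with wide uncertainty. The expected value of compound 4 is 54% with an estimated range of 30% to 78% on this read-out.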

Compound 4, percent of the compound remaining: 50%
Beside the measured number, compound 4's estimate is 4 percentage points above it; the measured number falls inside the stated range.
By their numbers in this assay, from the lowest: compound 2; then compounds 3 and 4 (each within the scatter of the next); then compound 1.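

The step of a number 4 percentage points higher from compound 3 to compound 4 (within the scatter) shows that, in this assay, the entering group with its hydrogen-bond donor reads level with the oxygen-containing group on the carbonyl carbon. The step of a number 35 percentage points higher from compound 2 to compound 4 (beyond the scatter) shows that a second group also stands well clear of the sulfur-containing group of compound 2, so the low value at this place is confined to compound 2 among these three. Nothing shown accounts for these values.

As far as these compounds go, what a methyl group on the nitrogen of the entering group, or a chlorine on that group, would do remains open.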